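Notes on the step from compound 3 to compound 4

The source may hold more compounds than are shown below. What is called first, only, known or untested is meant among the compounds shown, and "the series" means these compounds.

Measured in a functional assay on PANC-1 cells (Homo sapiens) for cytotoxicity, read by WST assay, with a stated time of 24 h; on this read-out lower numbers stand for stronger inhibition and higher numbers for weaker inhibition:
- compound 1 `O=C(CCCCCCCCCc1ccccc1)N1CCCCC1`: > 100000 nM, a limit
- compound 2 `O=C(CCCCCCCCc1ccc(O)cc1)N1CCCCC1`: > 100000 nM, a limit
- compound 3 `COc1ccc(CCCCCCCCC(=O)N2CCCCC2)cc1`: 89300 nM

Among the measured compounds shown here, compound 3, at 89300 nM, holds the only actual number in this assay. The rest of the series offers only (the limit of > 100000 nM in this assay, at which 2 of the 3 values shown sit).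

Compound 4 `O=C(CCCCCCCCc1cccc(F)c1)N1CCCCC1` differs from compound 3 as follows: 3-fluorophenyl in place of 4-methoxyphenyl on a saturated chain carbon, eight bonds along the chain from a carbonyl carbon.

For the measured compounds named here, two measured steps bear on this change, both involving the group that leaves: an at least 1.1-fold lower number from compound 1 to compound 3 (0.04 log units; that floor lies within the scatter), and an at least 1.1-fold lower number from compound 2 to compound 3 (0.04 log units; that floor lies within the scatter). Both are floors only. The third is a step that the two limits leave unreadable from compound 1 to compound 2. Going by the values given here, no measured compound carries 3-fluorophenyl, so the direction of the change rests on little. Among the compounds with values here, with compound 3 at 89300 nM as the sole reference, a large move in this assay has no support in these steps. The expected result is a 1.1-fold higher number from compound 3 to compound 4 (0.03 log units; within the scatter), with no shift beyond the scatter foreseen, and a reading at the limit is quite possible. For compound 4 the estimate is 95000 nM, with an expected range of 50000 nM to 180000 nM.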

Compound 4, half-maximal inhibitory concentration: > 100000 nM
Compound 4 gave a limit, no number; the forecaster's own chance of this, stated with the estimate: 55%; middle value at least 1.0-fold (0.02 log units) away from the limit.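

In this assay, 3-fluorophenyl on this saturated chain carbon, eight bonds along the chain from a carbonyl carbon, gives no readable number, and the series sits mostly at one ceiling: the limit of > 100000 nM in this assay, at which 3 of the 4 values shown sit. On these data alone, the change from 4-methoxyphenyl to 3-fluorophenyl is bounded only by a floor, an at least 1.1-fold higher number from compound 3 to compound 4 (0.04 log units; that floor lies within the scatter), so no shift beyond the scatter can be claimed, though its true size stays unknown. The steps to compound 4 from compound 1 and from compound 2 cannot be read, as both ends of each are limits.

As far as these compounds go, how far the limit values lie from a true number remains open. Also open, from the compounds shown here alone, is whether an amine or a carboxylic acid on the aromatic ring, or a longer chain, would move the series clearly away from compound 3 at 89300 nM.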